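Lengthening the chain to a phenoxyethyl end

This account rests on a few compounds, and the source may have more. Where it says the series, first, only, none or still open, it means among the compounds named here.

Measured so far:
- compound 1, `Cc1cc(C)c(NC(=O)C(C)(C)CCCCc2ccccc2)c2c1CC(C)(C)O2`: 210 nM
- compound 2, `Cc1cc(C)c(NC(=O)C(C)(C)CCCCCCc2ccccc2)c2c1CC(C)(C)O2`: 81 nM
- compound 3, `Cc1cc(C)c(NC(=O)C(C)(C)CCCOc2ccc(Cl)cc2)c2c1CC(C)(C)O2`: 260 nM

All three share the same core and amide, and differ only in the chain that hangs from the carbonyl side. In an assay for inhibition of acyl-CoA:cholesterol acyltransferase (Oryctolagus cuniculus), using microsomes (on this read-out higher numbers stand for weaker inhibition and lower numbers for stronger inhibition), compound 3 gives the highest of the three numbers, close to compound 1 and separated from compound 2 by a 3.2-fold higher number from compound 2 to compound 3 (0.51 log units; beyond the scatter). The step of a 1.2-fold higher number from compound 1 to compound 3 (0.09 log units; within the scatter) shows that swapping benzyl for 4-chlorophenoxy at this position changes little.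

Compound 4, `Cc1cc(C)c(NC(=O)C(C)(C)CCCCCOc2ccccc2)c2c1CC(C)(C)O2`, carries 2-phenoxyethyl in place of 4-chlorophenoxy on a saturated chain carbon, four bonds along the chain from a carbonyl carbon. The change that bears most on this is a 2.6-fold lower number from compound 1 to compound 2 (0.41 log units; beyond the scatter), where the chain was lengthened by two carbons and the number fell. Compound 4 matches compound 2 in chain length, so a step of similar size and direction is expected here.

Compound 4 is therefore estimated at 110 nM, within a range of 45 nM to 270 nM, which means an expected step of a 2.4-fold lower number from compound 3 to compound 4 (0.37 log units; beyond the scatter).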

Compound 4, half-maximal inhibitory concentration: 86 nM
Estimate against measurement, compound 4: 1.3-fold (0.11 log units) above; the range from low to high includes it.
By their numbers in this assay, from the lowest: compounds 2 and 4 (each within the scatter of the next); then compounds 1 and 3 (each within the scatter of the next).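

In this assay, the gain from the longer chain now appears with an oxygen in the chain as well as with carbon alone (a 2.4-fold lower number from compound 1 to compound 4 (0.39 log units; beyond the scatter)). At the longer length, phenoxy in place of benzyl, six bonds along the chain from a carbonyl carbon, leaves the number within the scatter (a 1.1-fold higher number from compound 2 to compound 4 (0.03 log units; within the scatter)), so this oxygen costs nothing measurable here. The drop on going from the 4-chlorophenoxy end is also beyond the scatter (a 3.0-fold lower number from compound 3 to compound 4 (0.48 log units; beyond the scatter)), but that step lengthens the chain and removes the chlorine together, so neither change can be credited alone.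

A 2-(4-chlorophenoxy)ethyl group would separate those two changes, and a still longer chain would show whether the gain continues. No outside evidence here explains why the numbers move.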